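Working notes: cytotoxicity across compounds 1 to 4

A few compounds are considered here, and "the series" means these few. Any claim that something is new, unique, unknown or untested is made for them only; others in the source may bear on it.

Compound 1 `c1ccc(-c2ccc(Cn3cncc3CNc3cccc(-c4ccccc4)c3)cc2)cc1`: in a toxicity assay on NIH3T3 cells (Mus musculus) for cytotoxicity, read by resazurin assay (on this read-out lower numbers stand for an effect already at smaller amounts and higher numbers for an effect only at larger amounts of compound), compound 1 gives 10000 nM.
Compound 2 `c1ccc(-c2ccc(Cn3cncc3CNc3ccc(-c4onc5ccccc45)c(-c4ccccc4)c3)cc2)cc1`: in this assay compound 2 gives only a limit, > 10000 nM.
Compound 3 `N#Cc1ccc(NCc2cncn2Cc2ccc(-c3ccccc3)cc2)cc1-c1ccccc1`: in this assay compound 3 gives only a limit, > 1000 nM.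

Compound 3 thus stands at a limit, not a number; the one other limit in the set is that of compound 2. The steps touching it are unreadable: a step that the limit leaves unreadable from compound 1 to compound 3 and a step that the two limits leave unreadable from compound 2 to compound 3. The remaining step, a number no lower from compound 1 to compound 2 (the limit leaves the size open), is at least flat. Compound 4 `c1ccc(-c2ccc(Cn3cncc3CNc3ccc(-c4cc5ccccc5o4)c(-c4ccccc4)c3)cc2)cc1` carries the change (1-benzofuran-2-yl in place of cyano on an aromatic carbon). It resembles compound 2, which sits at the limit of > 10000 nM in this assay, at which 1 of the 3 values shown sits. Compound 4 is therefore expected to give 10000 nM, with a range from 3000 nM to 30000 nM, most likely again only a limit. The expected step is a step that the limit leaves unreadable from compound 3 to compound 4, unreadable against the limit of compound 3.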

Compound 4, half-maximal effective concentration: > 10000 nM
Compound 4 gave a limit, no number; the forecaster's own chance of this, stated with the estimate: 70%; the middle value sits exactly at the limit.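

In this assay compound 4 gives only a limit, > 10000 nM. With 1-benzofuran-2-yl at this place, ortho to a phenyl group, the comparison with the unsubstituted core reads a number no lower from compound 1 to compound 4 (the limit leaves the size open). Compound 2 and compound 4, with two different groups of 9 heavy atoms here, now share one limit: the limit of > 10000 nM in this assay, at which 2 of the 4 values shown sit.

From the compounds shown here alone, the other new steps cannot be read, and the real values of compound 2 and compound 4 stay open. Also open, going by these compounds, is whether an amine or a carboxylic acid at this place would give a number.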